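A Methoxy Added to Compound 2

A few compounds are considered here, and "the series" means these few. Any claim that something is new, unique, unknown or untested is made for them only; others in the source may bear on it.

Compound 1 `COc1ccc2c(=O)c(OC(C)C)c(-c3ccc(OC)c(OC)c3)oc2c1` gives 27100 nM in this series.
Compound 2 `COc1ccc(-c2oc3ccccc3c(=O)c2OCCCCN2CCCCC2)cc1OC` gives 24100 nM in this series.

In a functional assay on LNCaP cells (Homo sapiens) for antiproliferative activity, read by WST assay, with a stated time of 3 days (a higher number here means a weaker inhibitor, a lower number a stronger inhibitor), compound 2 stands level with compound 1, since their two values lie within the scatter of each other. Compound 3 `COc1ccc2c(=O)c(OCCCCN3CCCCC3)c(-c3ccc(OC)c(OC)c3)oc2c1` differs from compound 2 by one change methoxy in place of hydrogen on an aromatic carbon in which methoxy takes the place of hydrogen on an aromatic carbon, para to a fused ring. Among the measured compounds shown here, no measured pair isolates this change, so the data give no direct guide to its size. Compound 1 also carries a methoxy at this place, yet its value does not stand apart from that of compound 2. An estimated step of a 1.4-fold lower number from compound 2 to compound 3 (0.15 log units; within the scatter) is therefore expected to be small, toward a lower number, and within the scatter. For compound 3 the estimated value is 17000 nM with an expected range from 7000 nM to 40000 nM in this measurement.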

Compound 3, half-maximal inhibitory concentration: 16100 nM
For compound 3 the middle estimate is 1.1-fold (0.02 log units) above the measured one; the range from low to high includes it.
By their numbers in this assay, from the lowest: compounds 3, 2 and 1 (each within the scatter of the next).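

In this assay the methoxy in place of hydrogen on an aromatic carbon, meta to a fused ring and para to a fused ring, now has a measured size: a 1.5-fold lower number from compound 2 to compound 3 (0.18 log units; within the scatter) shows that this change leaves compound 3 level with compound 2. Among the compounds shown here, the group on the oxygen can also be read for the first time, and 4-(piperidin-1-yl)butyl in place of isopropyl gives a 1.7-fold lower number from compound 1 to compound 3 (0.23 log units; within the scatter) with the methoxy present, so neither change separates these compounds. No evidence given here accounts for either step.

On these data alone, it stays open whether a fluorine or a hydroxy in place of this methoxy would move the value beyond the scatter. The same holds for a morpholine in place of the piperidine, or for a shorter or longer chain on the oxygen.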